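The source may hold more compounds than are shown below. What is called first, only, known or untested is meant among the compounds shown, and "the series" means these compounds.

Compound 1 `Cc1ccsc1C(c1ccccc1Br)N1CCN(c2ncnc3c2cnn3-c2ccccc2)CC1`: in a functional assay on cells (Rhabdomyosarcoma cell, Homo sapiens) for cytotoxicity (on this read-out lower numbers stand for stronger inhibition and higher numbers for weaker inhibition), compound 1 gives > 25000 nM.
Compound 2 `c1ccc(C(c2cccnc2)N2CCN(c3ncnc4c3cnn4-c3ccccc3)CC2)cc1`: in this assay compound 2 gives > 25000 nM.

Both results are limits of the measurement, not numbers. In this assay compound 2 stands only at a limit, and the same holds for the other measured compound, as the limit of > 25000 nM in this assay, at which 2 of the 2 values shown sit, shows. Compound 3 `Cc1ccsc1C(c1ccccc1)N1CCN(c2ncnc3c2cnn3-c2ccccc2)CC1` carries 3-methylthiophen-2-yl in place of pyridin-3-yl on a saturated chain carbon bound to an amine nitrogen in a ring and an aromatic carbon. Among the measured compounds shown here, no step between measured compounds exists here, so the size of this change cannot be read from the data. Given (the limit of > 25000 nM in this assay, at which 2 of the 2 values shown sit), compound 3 is expected to remain at the limit, with a step that the limit leaves unreadable from compound 2 to compound 3 meaning no shift beyond the scatter. Compound 3 is therefore estimated at 40000 nM, between 12000 nM and 150000 nM.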

Compound 3, half-maximal inhibitory concentration: > 25000 nM
Compound 3 was reported as a limit; the forecaster's own chance of this, stated with the estimate: 85%; the middle value is on the limit's open side.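

Compound 3 joins compound 1 and compound 2 at a limit of the measurement, so no step among these three compounds can be read in this assay. The compounds shown leave open what any of these changes does to cytotoxicity: the limit of > 25000 nM in this assay, at which 3 of the 3 values shown sit.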